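Swapping thiophene for phenyl on the sulfonyl group

This account rests on a few compounds, and the source may have more. Where it says the series, first, only, none or still open, it means among the compounds named here.

Compound 1 `O=C(NC[C@H](NS(=O)(=O)c1ccc(Cl)cc1)C(=O)O)c1cc2cc(CCC3CCNCC3)sc2s1` at 11 nM
Compound 2 `O=C(NC[C@H](NS(=O)(=O)c1cccs1)C(=O)O)c1cc2sc(CCC3CCNCC3)cc2s1` at 13 nM

In a functional assay for inhibition, with Homo sapiens as the target (a lower number here means a stronger inhibitor, a higher number a weaker inhibitor), compound 2 gives 13 nM and compound 1 gives 11 nM in the same range. These two numbers lie within the scatter of repeated measurements, so neither compound can be ranked over the other.

Compound 3 `O=C(NC[C@H](NS(=O)(=O)c1ccccc1)C(=O)O)c1cc2sc(CCC3CCNCC3)cc2s1` is compound 2 with a single change, phenyl in place of thiophen-2-yl on a sulfonyl sulfur. For the measured compounds named here, no two measured compounds differ in only one place, so no measured step can guide this swap. Without such evidence, no shift beyond the scatter in this assay is expected in either direction. The estimated change is small (a 1.2-fold higher number from compound 2 to compound 3 (0.06 log units; within the scatter)) and the margin is kept wide. For compound 3 the expected value is 15 nM with an estimated range from 5 nM to 45 nM as the likely span.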

Compound 3, half-maximal inhibitory concentration: 8 nM
Compound 3: the middle estimate sits 1.9-fold (0.27 log units) above what was measured; low and high end bracket the measured number.
By their numbers in this assay, from the lowest: compounds 3, 1 and 2 (each within the scatter of the next).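

In this assay, for the compounds shown here, the position on the sulfonyl sulfur now has its first direct test: only this group differs, with phenyl in place of thiophen-2-yl, and the step reads (a 1.6-fold lower number from compound 2 to compound 3 (0.21 log units; within the scatter)). A five-membered aromatic ring with one hetero atom can therefore give way to a six-membered aromatic ring of carbon only at this position without a shift that stands out from the scatter of repeated measurements. Nothing measured here explains why the two rings read alike.

Going by these compounds, it remains open how this position would respond to a different kind of group, such as a pyridine ring, a methyl group or a phenyl ring carrying an amine. On these data alone, it is also open whether the same swap would read the same way on the core of compound 1.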